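Nitro-heteroaryl chalcones: cytotoxicity on Vero cells, butyl to tert-butyl

The source may report more compounds than this note shows. Statements on the series, on what has been measured and on what is new or still open speak of the compounds shown alone.

Measured compounds:
- compound 1 `CCCCc1ccc(C(=O)/C=C/c2ccc([N+](=O)[O-])s2)cc1`: 81300 nM
- compound 2 `O=C(/C=C/c1cccc([N+](=O)[O-])c1)c1ccc(N2CCCCC2)cc1`: "not determined" (no result reported)
- compound 3 `CSc1ccc(C(=O)/C=C/c2ccc([N+](=O)[O-])o2)cc1`: 40700 nM

Working notes on the series. The read-out is an ADME assay on Vero cells (Chlorocebus sabaeus) for cytotoxicity, read by resazurin assay, with a stated time of 72 h; a lower number here means that less compound is tolerated, a higher number that more compound is tolerated. In this assay compound 1 gives 81300 nM, the higher of the two numbers obtained so far; compound 3 gives 40700 nM, which is a step from compound 1 within the scatter, so the two cannot be ordered. For compound 2 the result in this assay is "not determined" (no result reported), and no number can be drawn from it. For the measured compounds named here, no pair of compounds differing in a single place has been measured, so no step on the numbers is available.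

The next compound is compound 4 `CC(C)(C)c1ccc(C(=O)/C=C/c2ccc([N+](=O)[O-])s2)cc1`. Compared with compound 1 the difference is tert-butyl in place of butyl on an aromatic carbon. The two have the same atoms joined differently, and the group that enters has the same count of heavy atoms, donors and acceptors as the group that leaves.

With nothing measured on a comparable step, the expected change is none beyond the scatter: the estimate is a 1.2-fold lower number from compound 1 to compound 4 (0.06 log units; within the scatter) in this assay. Compound 4 is therefore expected to give about 70000 nM in this assay, with a range from 30000 nM to 160000 nM.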

Compound 4, half-maximal cytotoxic concentration: > 100000 nM
Compound 4: a limit, no number; the forecaster's own chance of this, stated with the estimate: 12%; at least 1.4-fold (0.15 log units) between middle value and limit.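

In this assay compound 4 gives > 100000 nM, which is a limit of the assay and not a number. For the compounds shown here, this provides the first step that differs in one place: tert-butyl in place of butyl on an aromatic carbon, para to a large group, gives an at least 1.2-fold higher number from compound 1 to compound 4 (0.08 log units; that floor lies within the scatter), so only a floor is known for the change, and that floor does not separate the two compounds. At this position the exchange of one chain shape for the other therefore brings no lower number, while the real size of the step cannot be read, since the reading ends at a limit: the limit of > 100000 nM in this assay, at which 1 of the 4 values shown sits.

The compounds shown leave open how the number would respond at this position to a longer chain, an amine or a carboxylic acid in place of butyl. They also leave open whether the same exchange of butyl for tert-butyl would give a step of the same direction on the core of compound 3, or one that could be read as a number rather than a floor.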